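Three Hydroxyphenyl Isomers and a Fourth Still to Come

The source may hold more compounds than are shown below. What is called first, only, known or untested is meant among the compounds shown, and "the series" means these compounds.

Three compounds share one core and differ only in where a hydroxyl sits on one of the attached phenyl rings. Compound 1 `Oc1ccccc1-c1cc(-c2ccsc2)cc(-c2ccccc2O)n1` carries a 2-hydroxyphenyl group, compound 2 `Oc1cccc(-c2cc(-c3ccsc3)cc(-c3ccccc3O)n2)c1` carries a 3-hydroxyphenyl group, and compound 3 `Oc1ccc(-c2cc(-c3ccsc3)cc(-c3ccccc3O)n2)cc1` carries a 4-hydroxyphenyl group. All three were tested in a functional assay on HeLa cells (Homo sapiens) for cytotoxicity, read by CCK-8 assay; on this read-out lower numbers stand for stronger inhibition and higher numbers for weaker inhibition. In this assay compound 1 gives only a limit, > 50000 nM. Compound 2 likewise gives only a limit, > 50000 nM. Compound 3 too gives only a limit, > 50000 nM. Because every measured value sits at the limit of > 50000 nM in this assay, at which 3 of the 3 values shown sit, the steps between them cannot be sized: a step that the two limits leave unreadable from compound 1 to compound 2, a step that the two limits leave unreadable from compound 1 to compound 3 and a step that the two limits leave unreadable from compound 2 to compound 3 all remain unreadable.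

Compound 4 `Oc1ccc(-c2cc(-c3ccsc3)cc(-c3ccc(O)cc3)n2)cc1` has not yet been measured. It differs from compound 3 by 4-hydroxyphenyl in place of 2-hydroxyphenyl on an aromatic carbon; the two have the same atoms joined differently. Within the data shown here, none of the measured steps gives a readable size for this kind of change, so the data offer no direction beyond the scatter. In this assay the expected step is therefore a step that the limit leaves unreadable from compound 3 to compound 4, meaning no change that the scatter would not cover. Compound 4 is estimated at 80000 nM, with a range from 25000 nM to 300000 nM, and most likely the measurement will again report only a limit.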

Compound 4, half-maximal inhibitory concentration: 4370 nM
The estimate for compound 4 lay 18-fold (1.26 log units) above the measured number; measured number below the stated range.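

Among these compounds, the place next to the ring nitrogen turns out to matter in this assay: with 4-hydroxyphenyl in place of 2-hydroxyphenyl there, the result is an at least 11-fold lower number from compound 3 to compound 4 (1.05 log units; beyond the scatter), the first step in this set whose size can be read. The earlier steps shown here cannot be read, since compound 1, compound 2 and compound 3 all keep 2-hydroxyphenyl at this place, wherever the hydroxyl sits on the other ring, and each gives only a limit: the limit of > 50000 nM in this assay, at which 3 of the 4 values shown sit. A single 4-hydroxyphenyl group, as in compound 3, is therefore not enough to bring a number into range, whereas compound 4, with the same atoms joined differently, carries that group on both rings and alone in this set gives a measured value, 4370 nM.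

Going by these compounds, whether 3-hydroxyphenyl at this same place would also give a number stays open. The compounds shown also do not say whether the hydroxyl itself is required, as a methoxy group, an amine or a carboxylic acid in its stead would test, or whether the thiophen-3-yl group can be exchanged.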